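Pyridin-4-yl for 4-methylphenyl on the amide arm

This account rests on a few compounds, and the source may have more. Where it says the series, first, only, none or still open, it means among the compounds named here.

Measured compounds in a functional assay on A2780 cells (Homo sapiens) for cytotoxicity, read by MTT assay, with a stated time of 48 h; a higher number here means a weaker inhibitor, a lower number a stronger inhibitor:
- compound 1 `CN(C)CCCCN(C)C1=Nc2ccccc2C(CC(=O)NCc2ccccc2)N1c1ccc(-c2ccccc2)cc1`; compound 1 gives 1650 nM
- compound 2 `CN(C)CCCCCCN(C)C1=Nc2ccccc2C(CC(=O)NCc2ccccc2)N1c1ccc(-c2ccccc2)cc1`; compound 2 gives 1190 nM
- compound 3 `Cc1ccc(CNC(=O)CC2c3ccccc3N=C(N3CCN(CCN(C)C)CC3)N2c2ccc(-c3ccccc3)cc2)cc1`; compound 3 gives 1600 nM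

Compound 3 stands second highest of the three numbers. Its nearest neighbour is compound 1, within the scatter, and its furthest is compound 2, also within the scatter; the three values are indistinguishable on this reading.

Compound 4 `CN(C)CCN1CCN(C2=Nc3ccccc3C(CC(=O)NCc3ccncc3)N2c2ccc(-c3ccccc3)cc2)CC1` is the next member. It differs from compound 3 by pyridin-4-yl in place of 4-methylphenyl on a saturated chain carbon bound to an amide-type nitrogen. Going by the values given here, the only measured single-point step, a 1.4-fold lower number from compound 1 to compound 2 (0.14 log units; within the scatter), concerns the amine chain and not the amide arm, so it does not bear on this change. Among the compounds with values here, no measured pair varies the amide aryl group, and nothing in the numbers so far separates any compound from another beyond the scatter.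

The expectation for compound 4 is therefore a step of a 1.1-fold higher number from compound 3 to compound 4 (0.03 log units; within the scatter), that is, no change beyond the scatter in this assay. Compound 4 is estimated at 1700 nM, with a range of 600 nM to 5000 nM.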

Compound 4, half-maximal inhibitory concentration: > 5000 nM
Compound 4 gave a limit, no number; the forecaster's own chance of this, stated with the estimate: 5%; at least 2.9-fold (0.46 log units) between middle value and limit.
By their numbers in this assay, from the lowest: compounds 2, 3 and 1 (each within the scatter of the next). At a limit, above all of these: compound 4.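

In this assay compound 4 gives > 5000 nM, which is a limit of the assay and not a number. Going by these compounds alone, the step of an at least 3.1-fold higher number from compound 3 to compound 4 (0.49 log units; beyond the scatter) is the first beyond the scatter, and it falls on the amide arm, whereas the only earlier step, a 1.4-fold lower number from compound 1 to compound 2 (0.14 log units; within the scatter), concerns the amine chain, so the amide aryl group is a place where a single exchange can change the read-out. The size of this step remains a lower bound: the limit of > 5000 nM in this assay, at which 1 of the 4 values shown sits.

As far as these compounds go, it remains open whether the ring nitrogen of pyridin-4-yl or the loss of the methyl group of 4-methylphenyl carries the step. Pyridin-3-yl or 4-methoxyphenyl at the same place, with the amine chain of compound 3 kept, would separate these two readings.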